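Growing the Ring Nitrogen Substituent from Ethyl to Tert-Butyl

The compounds below may be only part of what the source reports. "The series", "measured", "known", "first", "only" and "open" are said of these compounds alone.

Two measured compounds share one core and differ at two places. Compound 1 `CN1C[C@H](C(=O)Nc2ccc(Br)cc2)[C@@H](c2ccc(/C=C/C(=O)Nc3ccccc3N)cc2)C1` gives 3 mL/min/kg in an in vitro ADME assay on microsomes from liver (Homo sapiens) for pharmacokinetics, read by LC-MS, with a stated time of 10 min, tested at 1 uM; a lower number here means slower removal, a higher number faster removal of the compound. Compound 2 `CCN1C[C@H](C(=O)Nc2ccc(Cl)cc2)[C@@H](c2ccc(/C=C/C(=O)Nc3ccccc3N)cc2)C1` gives 12 mL/min/kg in this assay, the higher of the two numbers, with compound 1 clearly lower. Compound 3 `CC(C)(C)N1C[C@H](C(=O)Nc2ccc(Cl)cc2)[C@@H](c2ccc(/C=C/C(=O)Nc3ccccc3N)cc2)C1` is not yet measured; it departs from compound 2 by tert-butyl in place of ethyl on an amine nitrogen in a ring. For the measured compounds named here, no measured pair shows this exchange, so its direction is unknown from these data. Compound 3 is expected to stay near compound 2, with an estimated step of no change at the digits printed from compound 2 to compound 3 (within the scatter) inside the usual scatter. The estimate for compound 3 is 12 mL/min/kg, with a range from 5 mL/min/kg to 28 mL/min/kg.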

Compound 3, clearance: 8 mL/min/kg
Estimate against measurement, compound 3: 1.5-fold (0.18 log units) above; measured number inside the range.
By their numbers in this assay, from the lowest: compound 1; then compounds 3 and 2 (each within the scatter of the next).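

In this assay the exchange of ethyl for tert-butyl on the amine nitrogen in the ring gives a 1.5-fold lower number from compound 2 to compound 3 (0.18 log units; within the scatter). For the compounds shown here, this is the first direct reading of this change, and with everything else in the molecule held fixed, the two groups cannot be told apart in this read-out. Nothing available here explains the result.

As far as these compounds go, whether a group holding a ring, such as cyclopropyl, or one carrying oxygen, such as 2-hydroxyethyl, would also stay this close remains open. So does whether tert-butyl behaves alike with bromine in place of chlorine on the phenyl ring.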